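A few compounds are considered here, and "the series" means these few. Any claim that something is new, unique, unknown or untested is made for them only; others in the source may bear on it.

Compound 1 `COc1ccc2[nH]c3c(c2c1)CCNC31CCN(Cc2cc(Cl)ccc2[N+](=O)[O-])CC1` is the starting point here. For the measured compounds named here, in an assay on FRT cells for positive allosteric modulation of Cystic fibrosis transmembrane conductance regulator variant N1303K (Homo sapiens), in the presence of a further agent that is not named here (on this read-out higher numbers stand for an effect only at larger amounts of compound and lower numbers for an effect already at smaller amounts), compound 1 gives 7100 nM, the highest of the three numbers known so far. Two measured compounds share its core and differ from it only in the group attached to the saturated chain carbon bound to an amine nitrogen in a ring. Compound 2 `COc1ccc2[nH]c3c(c2c1)CCNC31CCN(Cc2ccccc2Cl)CC1` carries a 2-chlorophenyl there and gives 2200 nM in this assay; the step from compound 1 to compound 2 is a 3.2-fold lower number from compound 1 to compound 2 (0.51 log units; beyond the scatter). Compound 3 `COc1ccc2[nH]c3c(c2c1)CCNC31CCN(Cc2ccc(Br)cc2F)CC1` carries a 4-bromo-2-fluorophenyl and gives 1600 nM; the step from compound 1 to compound 3 is a 4.4-fold lower number from compound 1 to compound 3 (0.65 log units; beyond the scatter). Between compound 2 and compound 3 the step is a 1.4-fold lower number from compound 2 to compound 3 (0.14 log units; within the scatter).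

Compound 4 `COc1ccc2[nH]c3c(c2c1)CCNC31CCN(Cc2ccc(F)c(Cl)c2F)CC1` has not been measured. It differs from compound 1 in one place: 3-chloro-2,4-difluorophenyl in place of 5-chloro-2-nitrophenyl on a saturated chain carbon bound to an amine nitrogen in a ring. Both measured steps that bear on this, from compound 1 to compound 2 and from compound 1 to compound 3, replaced the same 5-chloro-2-nitrophenyl with a phenyl carrying only halogens and both gave modest lower numbers. The step from compound 1 to compound 4 is therefore expected to be a 3.9-fold lower number from compound 1 to compound 4 (0.60 log units; beyond the scatter), a modest move to lower numbers. Compound 4 is estimated to give 1800 nM in this assay, with a range from 700 nM to 4500 nM.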

Compound 4, half-maximal effective concentration: 4500 nM
For compound 4 the middle estimate is 2.5-fold (0.40 log units) below the measured one, within the range that was stated.
By their numbers in this assay, from the lowest: compounds 3 and 2 (each within the scatter of the next); then compounds 4 and 1 (each within the scatter of the next).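

Swapping the 5-chloro-2-nitrophenyl for a phenyl carrying only halogens does not guarantee a clear gain at this position: the new change gives only a 1.6-fold lower number from compound 1 to compound 4 (0.20 log units; within the scatter), so in this assay compound 4 goes against the trend that compounds 2 and 3 had suggested. The halogens themselves make a difference here, since the step to 3-chloro-2,4-difluorophenyl is a 2.8-fold higher number from compound 3 to compound 4 (0.45 log units; beyond the scatter) from the 4-bromo-2-fluorophenyl and a 2.0-fold higher number from compound 2 to compound 4 (0.31 log units; beyond the scatter) from the 2-chlorophenyl, so which halogens the ring carries and where they sit can move the number beyond the usual scatter, a sensitivity that the near-equal compounds 2 and 3 did not reveal. Nothing available explains why this halogen pattern behaves differently from the other two.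

The compounds shown leave open how a plain phenyl, or a phenyl carrying a methoxy group or a nitrile, would fare on the saturated chain carbon bound to an amine nitrogen in a ring, and so whether any halogen is needed there at all. They also leave open which of the three halogens of compound 4 matters most, a question that a phenyl carrying a single fluorine or a single chlorine could begin to address.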